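This account rests on a few compounds, and the source may have more. Where it says the series, first, only, none or still open, it means among the compounds named here.

Values in a functional assay on HCT-116 cells (Homo sapiens) for antiproliferative activity, read by MTT assay, with a stated time of 72 h (on this read-out higher numbers stand for weaker inhibition and lower numbers for stronger inhibition), are these
Compound 1 `CCNC(=O)CCc1cccc2c1B(O)OC2` gives > 100000 nM (a limit)
Compound 2 `CC(C)(C)NC(=O)CCc1cccc2c1B(O)OC2` gives > 100000 nM (a limit)
Compound 3 `O=C(CCc1cccc2c1B(O)OC2)Nc1cccc(Br)c1` gives 1400 nM

Compound 3 holds the only number shown, and the other two rest on (the limit of > 100000 nM in this assay, at which 2 of the 3 values shown sit). Compound 4 `O=C(CCc1cccc2c1B(O)OC2)Nc1cccc(-c2ccc(F)cc2)c1` differs from it at one place: 4-fluorophenyl in place of bromo on an aromatic carbon. Within the data shown here, two measured steps bear on this change, an at least 71-fold lower number from compound 1 to compound 3 (1.85 log units; beyond the scatter) and an at least 71-fold lower number from compound 2 to compound 3 (1.85 log units; beyond the scatter), both large and beyond the scatter. Each brought in the 3-bromophenyl group on an amide-type nitrogen, but neither altered the bromo itself, so they guide the direction only loosely. A modest move to a lower number is expected, estimated as a 2.0-fold lower number from compound 3 to compound 4 (0.30 log units; within the scatter). Compound 4 is estimated at 700 nM, with an expected range from 150 nM to 4000 nM.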

Compound 4, half-maximal inhibitory concentration: 550 nM
Estimate against measurement, compound 4: 1.3-fold (0.10 log units) above, and the stated range covers the measured number.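

The earlier compounds shown here changed only the group on the amide-type nitrogen, whereas here the bromo itself is replaced, and this assay records a 2.5-fold lower number from compound 3 to compound 4 (0.41 log units; beyond the scatter). This aromatic carbon therefore takes a 4-fluorophenyl group, with its added aromatic ring, and the number still moves modestly lower. Nothing shown here gives a reason for this step. On these data alone, it remains open whether the ring or its fluorine carries the step, which a plain phenyl group would help settle. As far as these compounds go, how an amine or a carboxylic acid at this carbon would read also remains open.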